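A Flat Series Meets a New Side Chain

This account rests on a few compounds, and the source may have more. Where it says the series, first, only, none or still open, it means among the compounds named here.

Measured so far in a functional assay for inhibition (a higher number here means a weaker inhibitor, a lower number a stronger inhibitor), with these readings:

- compound 1 `CC(C)(C)c1cc(-c2cc(=O)c3ccc(OCCO)cc3o2)cc(C(C)(C)C)c1O` at 3000 nM
- compound 2 `CC(C)(C)c1cc(-c2cc(=O)c3ccc(OCc4ccc5ccccc5n4)cc3o2)cc(C(C)(C)C)c1O` at 3000 nM
- compound 3 `CC(C)(C)c1cc(-c2cc(=O)c3ccc(OCC(=O)N4CCCCC4)cc3o2)cc(C(C)(C)C)c1O` at 3000 nM

These three share one core and differ only in the group attached through an oxygen on an aromatic ring. Compound 3 reads 3000 nM and so stands level with compound 1 and compound 2 at the digits reported.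

The next to be tested is compound 4 `CCOC(=O)C(C)(C)Oc1ccc2c(=O)cc(-c3cc(C(C)(C)C)c(O)c(C(C)(C)C)c3)oc2c1` and its change is this: 1-(ethoxycarbonyl)-1-methylethyl in place of ((piperidin-1-yl)carbonyl)methyl on an oxygen on an aromatic ring which puts 1-(ethoxycarbonyl)-1-methylethyl in place of ((piperidin-1-yl)carbonyl)methyl on that same oxygen. The entering group has no ring.

Three measured steps exchange groups at this place: no change at the digits printed from compound 1 to compound 2 (within the scatter) and then no change at the digits printed from compound 1 to compound 3 (within the scatter) and finally no change at the digits printed from compound 2 to compound 3 (within the scatter) and none of them goes beyond the scatter. Within the data shown here, three quite different groups thus gave the same reading, but no measured compound carries the new group, so the evidence is only indirect. In this assay no step beyond the scatter is expected, in either direction. The expected size of the change is no change at the digits printed from compound 3 to compound 4 (within the scatter) on this estimate. For compound 4 the estimated value is 3000 nM with an expected range from 1200 nM to 7000 nM as its limits of confidence.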

Compound 4, half-maximal inhibitory concentration: 3000 nM
Beside the measured number, compound 4's estimate shows no gap at the digits printed; the measured number falls inside the stated range.
By their numbers in this assay, from the lowest: compounds 1, 2, 3 and 4 (each within the scatter of the next).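

In this assay the 1-(ethoxycarbonyl)-1-methylethyl group gives no change at the digits printed from compound 3 to compound 4 (within the scatter) and no change at the digits printed from compound 2 to compound 4 (within the scatter) and also no change at the digits printed from compound 1 to compound 4 (within the scatter) in the comparison with the other side chains. The flat reading at this oxygen on an aromatic ring therefore now extends to a fourth kind of group, one ending in an ethoxycarbonyl unit, so the series holds across 2-hydroxyethyl, (quinolin-2-yl)methyl, ((piperidin-1-yl)carbonyl)methyl and this new group, and no compound shown goes against that. Nothing available accounts for why these four readings agree, so the result describes the pattern but does not explain it.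

The compounds shown leave open whether any group on this oxygen can move the reading at all, for example a free carboxylic acid in place of the ethoxycarbonyl unit, or a chain ending in a primary amine. They also leave open how the reading would respond to a change elsewhere on the shared core, such as replacing the tert-butyl groups or the hydroxyl group, since all four compounds carry these unchanged.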